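A few compounds are considered here, and "the series" means these few. Any claim that something is new, unique, unknown or untested is made for them only; others in the source may bear on it.

Working notes on the series. In a physicochemical assay for metabolic stability, read by HPLC, in phosphate buffer, at pH 7.3 (a higher number here means that the compound lasts longer, a lower number that the compound disappears faster), compound 1 `CCCCCCCCCCCCCCCCOC(=O)Oc1ccc(COP(=O)(OCc2ccc(OC(=O)CC)cc2)OP(=O)(O)OP(=O)(O)OC[C@H]2O[C@@H](n3cc(/C=C/Br)c(=O)[nH]c3=O)C[C@@H]2O)cc1` gives 56 h, compound 2 `CCCCCCCCCCCCCCCCOC(=O)Oc1ccc(COP(=O)(OCc2ccc(OC(=O)CC)cc2)OP(=O)(O)OP(=O)(O)OC[C@H]2O[C@@H](n3ccc(=O)[nH]c3=O)C[C@H]2N=[N+]=[N-])cc1` gives 68 h and compound 3 `CCCCCCCCCCCCCCCCOC(=O)Oc1ccc(COP(=O)(OCc2ccc(OC(=O)CC)cc2)OP(=O)(O)OP(=O)(O)OC[C@H]2O[C@@H](n3cc(Cl)c(=O)[nH]c3=O)C[C@@H]2F)cc1` gives 56 h. Compound 3 is level with compound 1 at the digits shown, and its gap to compound 2 lies within the scatter, so the three values cannot be ranked. No two of these compounds differ in one place only, so no measured step is available as a guide.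

Compound 4 `CCCCCCCCCCCCCCCCOC(=O)Oc1ccc(COP(=O)(OCc2ccc(OC(=O)CCCC)cc2)OP(=O)(O)OP(=O)(O)OC[C@H]2O[C@@H](n3cc(Cl)c(=O)[nH]c3=O)C[C@@H]2F)cc1` differs from compound 3 by a single change: ethyl in place of hydrogen on a saturated chain carbon, two bonds along the chain from a carbonyl carbon. The same difference reads propanoyl to butylcarbonyl. All three measured compounds carry the propanoyl group, so the data hold no test of this change.

No step beyond the scatter is expected in this assay, since compound 2 still gives 68 h with its differences from compound 3. The expected step, a 1.1-fold higher number from compound 3 to compound 4 (0.04 log units; within the scatter), stays within the scatter. For compound 4 the estimated value is 62 h, with an expected range of 35 h to 110 h.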

Compound 4, half-life: 66 h
Estimate against measurement, compound 4: 1.1-fold (0.03 log units) below, and the stated range covers the measured number.
By their numbers in this assay, from the lowest: compounds 1, 3, 4 and 2 (each within the scatter of the next).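

The propanoyl to butylcarbonyl change now has a first direct reading: in this assay the result is a 1.2-fold higher number from compound 3 to compound 4 (0.07 log units; within the scatter) for this single pair. Ethyl in place of hydrogen on a saturated chain carbon, two bonds along the chain from a carbonyl carbon, is therefore tolerated at this position without a step that can be told from the scatter, although the earlier compounds held no test of it. No evidence is available that bears on the reason for this result.

Going by these compounds, whether a longer chain, an amine or a carboxylic acid in place of the ethyl would give a step beyond the scatter remains open. On these data alone, it also remains open whether the same change would read alike on the core of compound 1 or of compound 2.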